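Chloro for Fluoro on a Shared Core: Lipophilicity

The source may hold more compounds than are shown below. What is called first, only, known or untested is meant among the compounds shown, and "the series" means these compounds.

Of the compounds shown here, three of this set have been measured in a physicochemical assay for lipophilicity; on this read-out lower numbers stand for lower lipophilicity and higher numbers for higher lipophilicity. Compound 1 `O=C1/C(=C/c2ccc(F)cc2)CCC/C1=C\c1ccccc1[N+](=O)[O-]` gives 4.86 in this assay. Compound 2 `O=C1/C(=C/c2ccc(F)cc2)CCC/C1=C\c1ccc([N+](=O)[O-])cc1` gives 5.08, and compound 3 `O=C1/C(=C/c2ccc(Cl)cc2)CCC/C1=C\c1ccc([N+](=O)[O-])cc1` gives 5.08. The difference between the cores of compound 1 and compound 2 is not broken down here; the two are built from the same atoms joined differently, and their values lie within the scatter of each other.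

From compound 2 to compound 3 the change is chloro in place of fluoro on an aromatic carbon, and the step it made in this assay was no change at the digits printed from compound 2 to compound 3 (within the scatter). Compound 4 `O=C1/C(=C/c2ccc(Cl)cc2)CCC/C1=C\c1ccccc1[N+](=O)[O-]` awaits measurement. Its relation to compound 1 is the same change, (chloro in place of fluoro on an aromatic carbon), made at the same place.

For the measured compounds named here, since the one measured instance of this change, from compound 2 to compound 3, moved the read-out by no change at the digits printed from compound 2 to compound 3 (within the scatter), the step from compound 1 to compound 4 is expected to be similarly small, a number 0.09 log units higher from compound 1 to compound 4 (within the scatter). Compound 4 is therefore estimated to give 4.95 in this assay, expected between 4.65 and 5.3.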

Compound 4, partition coefficient: 4.86
Compound 4: middle estimate off by 0.09 log units, on the high side; low and high end bracket the measured number.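

In this assay the replacement of 4-fluorophenyl by 4-chlorophenyl gave no change at the digits printed from compound 1 to compound 4 (within the scatter) and thus matched no change at the digits printed from compound 2 to compound 3 (within the scatter) in the earlier pair, so in both cores shown the change left the read-out within the scatter. This shows that the result carried from one core to the other in this pair of cases, but two instances do not establish a rule for the series, and a step within the scatter cannot show whether the change has a small effect or none. Nothing in the data shown gives a reason for this agreement between the two cores.

The compounds shown leave open how a bromo, a methoxy or a carboxylic acid on the same aromatic carbon would read in this assay on either core. They also leave open whether the swap of fluoro for chloro would again stay within the scatter on a core carrying an amine in place of the nitro group.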